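A few compounds are considered here, and "the series" means these few. Any claim that something is new, unique, unknown or untested is made for them only; others in the source may bear on it.

In an assay on CHO cells for displacement of a labelled ligand from adenosine receptor A3 (Homo sapiens) (a higher number here means a weaker inhibitor, a lower number a stronger inhibitor), the measured set is: compound 1 `CCOC(=O)c1cnc(NCC2CCCCC2)n2nc(-c3ccco3)nc12` with 41.2 nM; compound 2 `CNc1ncc(C(=O)O)c2nc(-c3ccco3)nn12` with 15900 nM; compound 3 `CCNc1ncc(C(=O)O)c2nc(-c3ccco3)nn12` with 480 nM.

Compound 3 stands second highest of the three numbers in this assay; compound 2 sits higher, compound 1 lower. Compound 4 `COc1ccc(CNc2ncc(C(=O)O)c3nc(-c4ccco4)nn23)cc1` differs from compound 3 by 4-methoxyphenyl in place of methyl on a saturated chain carbon bound to a nitrogen on an aromatic ring. Within the data shown here, the only measured step at this place, a 33-fold lower number from compound 2 to compound 3 (1.52 log units; beyond the scatter), shows the number falling as the chain on that nitrogen grows. Compound 1 carries a longer chain on the same nitrogen and gives a lower number again, but it differs from compound 3 in two places, so it is only a pointer. A further drop beyond the scatter is therefore expected, an 8.0-fold lower number from compound 3 to compound 4 (0.90 log units; beyond the scatter). For compound 4 the estimated value is 60 nM, with a range of 12 nM to 300 nM.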

Compound 4, inhibition constant: 5520 nM
The estimate for compound 4 lay 92-fold (1.96 log units) below the measured number; measured number outside the range, above it.
By their numbers in this assay, from the lowest: compound 1; then compound 3; then compound 4; then compound 2.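

Going from ethyl to 4-methoxybenzyl on this nitrogen gives a 12-fold higher number from compound 3 to compound 4 (1.06 log units; beyond the scatter) so the fall seen with chain growth does not continue in this assay for this change. The 4-methoxybenzyl chain still keeps some ground over methyl, with a 2.9-fold lower number from compound 2 to compound 4 (0.46 log units; beyond the scatter) so among these three acids the number does not follow chain size in one direction. Nothing measured here accounts for this reversal.

As far as these compounds go, whether a saturated propyl or butyl chain would fall further than ethyl stays open. So does whether unsubstituted benzyl would behave like 4-methoxybenzyl.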